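Adding a Methyl Group: From Compound 3 to Compound 4

The compounds below may be only part of what the source reports. "The series", "measured", "known", "first", "only" and "open" are said of these compounds alone.

Three compounds have been measured in a functional assay on HT-29 cells (Homo sapiens) for cytotoxicity, read by MTT assay, with a stated time of 24 h; a lower number here means a stronger inhibitor, a higher number a weaker inhibitor:

Compound 1 `CN(C)CCN1CCN(CC(=O)Nc2ccc(-c3nc4cc(F)ccc4o3)cc2)CC1`: 8190 nM
Compound 2 `Cc1cc(-c2nc3cc(F)ccc3o2)ccc1NC(=O)CN1CCN(CCN(C)C)CC1`: 6600 nM
Compound 3 `Cc1ccc2oc(-c3ccc(NC(=O)CN4CCN(CCCN(C)C)CC4)cc3)nc2c1`: 3890 nM

Compound 3 stands lowest of these three numbers. Its nearest neighbour is compound 2, whose number is higher by an amount within the scatter; compound 1 is furthest, higher by an amount beyond the scatter. Compound 4 `Cc1ccc2oc(-c3ccc(NC(=O)CN4CCN(CCCN(C)C)CC4)c(C)c3)nc2c1` differs from compound 3 in one place: methyl in place of hydrogen on an aromatic carbon.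

Among the compounds with values here, one measured step bears on this change, the same kind of methyl in place of hydrogen on an aromatic carbon: a 1.2-fold lower number from compound 1 to compound 2 (0.09 log units; within the scatter). That step stayed within the scatter, so in this assay no step beyond the scatter is expected; the expected step is a 1.1-fold lower number from compound 3 to compound 4 (0.05 log units; within the scatter). Compound 4 is therefore estimated at 3500 nM, with a range from 1700 nM to 7500 nM.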

Compound 4, half-maximal inhibitory concentration: 12700 nM
Beside the measured number, compound 4's estimate is 3.6-fold (0.56 log units) below it, and the stated range ends below it.
By their numbers in this assay, from the lowest: compounds 3, 2, 1 and 4 (each within the scatter of the next, the first and the last beyond it).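

On the core of compound 3, this methyl makes the compound a weaker inhibitor in this assay, with a 3.3-fold higher number from compound 3 to compound 4 (0.51 log units; beyond the scatter). The earlier step alone could not show that the same change, ortho to a large group, can have a different outcome on a different core: the same change on two cores in this assay, a 1.2-fold lower number (0.09 log units; within the scatter) from compound 1 to compound 2 and a 3.3-fold higher number (0.51 log units; beyond the scatter) from compound 3 to compound 4, 4.1-fold (0.61 log units) apart, beyond the scatter of two such steps

Still open, going by these compounds, is how a chlorine, a methoxy or an ethyl group at this carbon would compare with methyl and hydrogen on either core. Also open is which structural difference between the two cores lies behind the gap between these steps.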